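Swapping hydroxy for methyl on the aromatic ring

The source may hold more compounds than are shown below. What is called first, only, known or untested is meant among the compounds shown, and "the series" means these compounds.

- Compound 1 `CC1(C)[C@H]2CC[C@]1(C)N(Cc1cn(-c3ccc(C#N)cc3)nn1)C(=O)C2`: 90 nM
- Compound 2 `CC1(C)[C@H]2CC[C@]1(C)N(Cc1cn(-c3cccc(O)c3)nn1)C(=O)C2`: 410 nM

Both values come from a functional assay on LoVo cells (Homo sapiens) for inhibition, read by MTT assay, with a stated time of 24 h; a lower number here means a stronger inhibitor, a higher number a weaker inhibitor. Compound 2 has the higher of the two numbers at 410 nM, which makes it the weaker inhibitor of the pair.

Compound 3 `Cc1cccc(-n2cc(CN3C(=O)C[C@@H]4CC[C@@]3(C)C4(C)C)nn2)c1` departs from compound 2 in one place: methyl in place of hydroxy on an aromatic carbon. Methyl takes the place of hydroxy on an aromatic carbon, so 3-hydroxyphenyl becomes 3-methylphenyl.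

Among the compounds with values here, only one measured step bears on this, and only indirectly: a 4.6-fold higher number from compound 1 to compound 2 (0.66 log units; beyond the scatter). This modest step lies beyond the scatter, but it replaced 4-cyanophenyl with 3-hydroxyphenyl, a different exchange from the one here. It shows that changing the group on the aromatic nitrogen can move the number, but it gives neither the size nor the direction of a swap from hydroxy to methyl. Within the data shown here, no measured pair makes that swap, so a small change is the cautious expectation.

The expected result is a 1.2-fold lower number from compound 2 to compound 3 (0.07 log units; within the scatter), a step that would stay within the scatter. Compound 3 is estimated at 350 nM, with an expected range of 120 nM to 1000 nM.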

Compound 3, half-maximal inhibitory concentration: 50 nM
The estimate for compound 3 lay 7.0-fold (0.85 log units) above the measured number; measured number below the stated range.
By their numbers in this assay, from the lowest: compounds 3 and 1 (each within the scatter of the next); then compound 2.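

Within the data shown here, the swap of hydroxy for methyl at this ring position is not a neutral exchange: in this assay it gives an 8.2-fold lower number from compound 2 to compound 3 (0.91 log units; beyond the scatter) and takes compound 3 well clear of compound 2, even though only one heavy atom changes and the ring stays the same. The second comparison, a 1.8-fold lower number from compound 1 to compound 3 (0.26 log units; within the scatter), stays within the scatter, so 3-methylphenyl and 4-cyanophenyl on the aromatic nitrogen cannot be told apart here, and compound 2, with its 3-hydroxyphenyl group, is the only one of the three that stands out as a weaker inhibitor. No measurement of any other kind is available to explain why the methyl compound gives the lower number.

The compounds shown leave open whether the hydroxy group is unusual at this position or methyl is simply one of many groups that work there, a question that a methoxy group, an amine, a chlorine atom or a longer chain such as ethyl could help settle. They also leave open how much of the difference depends on the group's place on the ring, since methyl appears at only one position.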